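The source may hold more compounds than are shown below. What is called first, only, known or untested is meant among the compounds shown, and "the series" means these compounds.

In a functional assay on HeLa cells (Homo sapiens) for inhibition, read by MTT assay, with a stated time of 72 h (on this read-out higher numbers stand for weaker inhibition and lower numbers for stronger inhibition), the measured compounds are these

Compound 1 `Fc1ccc(-c2nnc(SCCCN3CCN(c4nc5ccccc5o4)CC3)o2)cc1` gives 196000 nM
Compound 2 `Brc1ccc(-c2nnc(SCCCN3CCN(c4nc5ccccc5o4)CC3)o2)cc1` gives 187000 nM
Compound 3 `Fc1ccc(-c2nnc(SCCCN3CCN(c4nc5ccccc5s4)CC3)o2)cc1` gives 134000 nM

The three values lie close together. Compound 3, at 134000 nM, is within the usual scatter of both compound 1 and compound 2, so no order among them can be claimed.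

The next compound to be measured is compound 4 `O=C(NCc1nnc(SCCCN2CCN(c3nc4ccccc4s3)CC2)o1)c1ccccc1`. Compared with compound 3, it has benzamidomethyl in place of 4-fluorophenyl on an aromatic carbon of a five-membered aromatic ring with 2 nitrogen and 1 oxygen (benzamidomethyl in place of 4-fluorophenyl on an aromatic carbon).

Two measured steps offer some guidance. Bromo in place of fluoro on an aromatic carbon gave a 1.0-fold lower number from compound 1 to compound 2 (0.02 log units; within the scatter), and 1,3-benzothiazol-2-yl in place of 1,3-benzoxazol-2-yl gave a 1.5-fold lower number from compound 1 to compound 3 (0.17 log units; within the scatter). Neither step replaces the whole 4-fluorophenyl group, so the data do not test this change directly. Still, with both steps as small as a 1.0-fold lower number from compound 1 to compound 2 (0.02 log units; within the scatter) and a 1.5-fold lower number from compound 1 to compound 3 (0.17 log units; within the scatter), no shift beyond the scatter is expected in this assay, in either direction. The expected step is a 1.0-fold higher number from compound 3 to compound 4 (0.02 log units; within the scatter). For the measured compounds named here, for compound 4 the estimate is 140000 nM, with an expected range from 60000 nM to 320000 nM, kept wide because no measured step covers this swap.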

Compound 4, half-maximal inhibitory concentration: 78100 nM
Estimate against measurement, compound 4: 1.8-fold (0.25 log units) above; the range from low to high includes it.
By their numbers in this assay, from the lowest: compounds 4, 3, 2 and 1 (each within the scatter of the next, the first and the last beyond it).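

In this assay, putting benzamidomethyl in place of 4-fluorophenyl on this aromatic carbon of the five-membered ring leaves the number within the scatter (a 1.7-fold lower number from compound 3 to compound 4 (0.23 log units; within the scatter)). The earlier steps shown here changed only a halogen on the outer benzene ring or the fused ring system on the amine nitrogen, whereas this one replaces the whole group on the ring. It shows that this position can carry a larger group, with a carbonyl and an amide hydrogen added and the benzene ring set further out, with no shift beyond the scatter, though no measurement here offers an explanation for that.

The compounds shown leave open whether the amide contributes anything in this position, since benzamidomethyl differs from 4-fluorophenyl in several ways at once; a plain benzyl group would separate the amide from the added length, and a longer chain between the ring and the amide would test how far the benzene ring can sit. They also leave open whether the same swap behaves alike with 1,3-benzoxazol-2-yl on the amine nitrogen, or whether a small group such as methyl or an amine fits this position equally well.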